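Notes on a pyranoquinolinone-type series: step to compound 3

The compounds below may be only part of what the source reports. "The series", "measured", "known", "first", "only" and "open" are said of these compounds alone.

Measured so far:
compound 1 `CCOc1cc(=O)n(CCCO)c2c1CC(CC=C(C)C)C(C)(C)C2`: 66.5%
compound 2 `CC(C)=CCC1Cc2c(OCCCNC(=O)c3cccs3)cc(=O)n(CCCO)c2CC1(C)C`: 33.6%

In a functional assay on PANC-1 cells (Homo sapiens) for inhibition, read by MTT assay, with a stated time of 24 h, tested at 10 uM (a higher number here means more inhibition at the concentration tested (going by the name of the read-out), a lower number less inhibition), compound 1 gives 66.5%. Compound 2 gives 33.6% and stands lowest of the two numbers; its nearest neighbour is compound 1, and the step of a number 32.9 percentage points lower from compound 1 to compound 2 (beyond the scatter) is the only one measured in the series. Compound 3 `COc1ccc(NC(=O)Oc2cc(=O)n(CCCO)c3c2CC(CC=C(C)C)C(C)(C)C3)cc1` is not yet measured. It differs from compound 2 by (4-methoxyphenyl)carbamoyl in place of 3-(((thiophen-2-yl)carbonyl)amino)propyl on an oxygen on an aromatic ring. For the measured compounds named here, no measured step bears directly on this change: the one step known concerns a different alteration on the same oxygen, so its size offers no firm guide here. Without a matching precedent, the number for compound 3 is expected to lie near that of compound 2, and the expected step of a number 8.4 percentage points higher from compound 2 to compound 3 (within the scatter) is taken as none beyond the scatter. Compound 3 is therefore estimated at 42%, within a range of 15% to 70%.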

Compound 3, a percentage reported as inhibition, at one concentration (the size of the read-out at that concentration, not a potency): 3.7%
The estimate for compound 3 lay 38.3 percentage points above the measured number; measured number below the stated range.
By their numbers in this assay, from the lowest: compound 3; then compound 2; then compound 1.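

In this assay, the substituent on this oxygen matters beyond its size: a number 29.9 percentage points lower from compound 2 to compound 3 (beyond the scatter) even though 3-(((thiophen-2-yl)carbonyl)amino)propyl and (4-methoxyphenyl)carbamoyl match in their counts of heavy atoms, hydrogen-bond donors and hydrogen-bond acceptors. Set against the ethyl of compound 1, the same carbamoyl group gives a number 62.8 percentage points lower from compound 1 to compound 3 (beyond the scatter) and so extends the drop first seen with the amide-bearing chain, leaving ethyl the best of the three groups on this oxygen. No measurement available here accounts for the difference between these groups.

The compounds shown leave open whether the carbamoyl link or the 4-methoxyphenyl ring goes with the low number, as the two enter together. A methylcarbamoyl group and a 4-methoxybenzyl ether on the same oxygen would separate them.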